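Adding a second hydroxy to compound 3

A few compounds are considered here, and "the series" means these few. Any claim that something is new, unique, unknown or untested is made for them only; others in the source may bear on it.

Measured in a functional assay on MDA-MB-231 cells (Homo sapiens) for cytotoxicity, read by ELISA, with a stated time of 2 days; a higher number here means a weaker inhibitor, a lower number a stronger inhibitor:
- compound 1 `Oc1ccccc1-c1cc(-c2ccccc2)cc(-c2ccccc2O)n1`: 37300 nM
- compound 2 `Oc1cccc(-c2cc(-c3ccccc3)cc(-c3ccccc3)n2)c1`: 19300 nM
- compound 3 `Oc1ccc(-c2cc(-c3ccccc3)cc(-c3ccccc3)n2)cc1`: 1300 nM

Compound 3 has the lowest number of the three at 1300 nM, well under compound 2 at 19300 nM and compound 1 at 37300 nM. The next compound, compound 4 `Oc1ccc(-c2cc(-c3ccccc3)cc(-c3ccc(O)cc3)n2)cc1`, differs from compound 3 by hydroxy in place of hydrogen on an aromatic carbon, para to a large group, turning a phenyl into a 4-hydroxyphenyl. Among the compounds with values here, only one measured step bears on this, and only indirectly: a 15-fold lower number from compound 2 to compound 3 (1.17 log units; beyond the scatter) is large, but it relocates a hydroxy rather than adding one. Compound 1 also carries two hydroxy groups, yet they sit differently, and it has no measured partner with a single hydroxy. Compound 4 keeps the 4-hydroxyphenyl of compound 3, so a much smaller change than that large step is expected, tending toward a higher number. The expected step is a 2.3-fold higher number from compound 3 to compound 4 (0.36 log units; beyond the scatter). For compound 4 the estimated value is 3000 nM, with an expected range of 500 nM to 20000 nM.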

Compound 4, half-maximal inhibitory concentration: 6700 nM
Estimate against measurement, compound 4: 2.2-fold (0.35 log units) below; the range from low to high includes it.
By their numbers in this assay, from the lowest: compound 3; then compound 4; then compounds 2 and 1 (each within the scatter of the next).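

In this assay, turning a phenyl of compound 3 into a 4-hydroxyphenyl gives a 5.2-fold higher number from compound 3 to compound 4 (0.71 log units; beyond the scatter), so this position, para to a large group, does respond to the change, and the added hydroxy goes with a weaker result. The earlier step, a 15-fold lower number from compound 2 to compound 3 (1.17 log units; beyond the scatter), only relocated a hydroxy, whereas this one adds a hydroxy while the 4-hydroxyphenyl of compound 3 stays in place, giving the only direct reading shown of a second hydroxy on that compound. No measurement is available that would explain this step.

From the compounds shown here alone, whether a methoxy, an amine or a carboxylic acid at this same place would move the number in the same direction remains open. Also open, going by these compounds, is what a further hydroxy on the remaining phenyl of compound 4 would do.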